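The compounds below may be only part of what the source reports. "The series", "measured", "known", "first", "only" and "open" are said of these compounds alone.

In a functional assay on HepG2 cells (Homo sapiens) for antiproliferative activity, read by CCK-8 assay, with a stated time of 48 h (a lower number here means a stronger inhibitor, a higher number a weaker inhibitor), compound 1 `O=C(Nc1ccccc1)c1cc(Oc2ccc(/C=C/c3ccncc3)cc2)ccn1` gives only a limit, > 100000 nM. Compound 2 `COc1ccc(NC(=O)c2cc(Oc3ccc(/C=C/c4ccncc4)cc3)ccn2)cc1` likewise gives only a limit, > 100000 nM. Both values rest at the limit of > 100000 nM in this assay, at which 2 of the 2 values shown sit, which leaves a step that the two limits leave unreadable from compound 1 to compound 2. Compound 3 `O=C(Nc1ccc(Cl)cc1)c1cc(Oc2ccc(/C=C/c3ccncc3)cc2)ccn1` differs from compound 2 by chloro in place of methoxy on an aromatic carbon. Within the data shown here, the single measured step offers no readable size or direction, so it cannot say whether this change helps or hurts. Compound 3 is therefore expected to stay weak, with an estimated step of a number no higher from compound 2 to compound 3 (the limit leaves the size open) that cannot be separated from scatter. The estimate for compound 3 is 100000 nM, with a range from 10000 nM to 1000000 nM.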

Compound 3, half-maximal inhibitory concentration: 56200 nM
For compound 3 the middle estimate is 1.8-fold (0.25 log units) above the measured one; measured number inside the range.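

At this position, para to a large group, chloro gives a readable number in this assay, which hydrogen and methoxy did not. Chloro in place of methoxy gives an at least 1.7-fold lower number from compound 2 to compound 3 (0.25 log units; that floor lies within the scatter), and chloro in place of hydrogen gives an at least 1.7-fold lower number from compound 1 to compound 3 (0.25 log units; that floor lies within the scatter). Both steps are only floors, and their full sizes stay unknown because the two starting compounds each rest at a limit: the limit of > 100000 nM in this assay, at which 2 of the 3 values shown sit.

As far as these compounds go, what an amine or a bromo group at this same position would give stays open.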